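The source may report more compounds than this note shows. Statements on the series, on what has been measured and on what is new or still open speak of the compounds shown alone.

Measured in a functional assay (ileum) for inhibition, with Cavia porcellus as the target; a higher number here means that more compound is needed for the effect, a lower number that less compound is needed:
- compound 1 `C[C@H](NC1=NS(=O)(=O)c2cccnc2N1)C1CCCCC1`: > 300 uM
- compound 2 `C[C@@H](NC1=NS(=O)(=O)c2cccnc2N1)C1CCCCC1`: > 300 uM

Both entries are limits, not numbers, so compound 1 has no readable position in the series, and the limit of > 300 uM in this assay, at which 2 of the 2 values shown sit, is all that can be said of its standing.

Compound 3 `C[C@H](NC1=NS(=O)(=O)c2cccnc2N1)c1ccccc1` is the next step, with phenyl in place of cyclohexyl on a saturated chain carbon bound to an amine nitrogen and a saturated chain carbon.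

For the measured compounds named here, the only measured step is a step that the two limits leave unreadable from compound 1 to compound 2, which reflects (the fact that compounds 1 and 2 differ only in the configuration as drawn). It concerns configuration rather than this group and gives no size to carry over, so no direction can be derived, and no step beyond the scatter is expected.

The expected step is a number no higher from compound 1 to compound 3 (the limit leaves the size open). Another limit is a likely outcome in this assay. For compound 3 the estimated value is 300 uM, with an expected range from 60 uM to 1000 uM.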

Compound 3, concentration for half-maximal effect: > 300 uM
Compound 3 gave a limit, no number; the forecaster's own chance of this, stated with the estimate: 65%; the middle value sits exactly at the limit.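

In this assay compound 3 gives > 300 uM, a limit and not a number. For the compounds shown here, compound 1 also sits at a limit, so no step from compound 1 to compound 3 can be read. The compounds shown leave open whether phenyl and cyclohexyl differ in this read-out at all.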